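Swapping the Benzimidazole for a Nitrogen-Richer Bicycle

The compounds below may be only part of what the source reports. "The series", "measured", "known", "first", "only" and "open" are said of these compounds alone.

Compound 1 `O=S(=O)(Nc1cc(-c2ccc3nc[nH]c3c2)cnc1Cl)c1ccc(F)cc1` — in an assay on U-87MG ATCC cells for inhibition of RAC-alpha serine/threonine-protein kinase (Homo sapiens), read by AlphaScreen, with a stated time of 2 h (on this read-out higher numbers stand for weaker inhibition and lower numbers for stronger inhibition), compound 1 gives > 12000 nM, which is a limit of the assay and not a number.
Compound 2 `Nc1nc2ccc(-c3cnc(Cl)c(NS(=O)(=O)c4ccc(F)cc4)c3)cc2[nH]1` — in this assay compound 2 gives > 12000 nM, again a limit.
Compound 3 `Nc1cn2cc(-c3cnc(Cl)c(NS(=O)(=O)c4ccc(F)cc4)c3)ccc2n1` — in this assay compound 3 gives > 12000 nM, also a limit.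

Compound 1 therefore stands only at a limit, and so do the other two, as the limit of > 12000 nM in this assay, at which 3 of the 3 values shown sit, records. Among the measured compounds shown here, the one single-point step measured, a step that the two limits leave unreadable from compound 1 to compound 2, cannot be read because both ends are limits.

Compound 4 `O=S(=O)(Nc1cc(-c2ccc3nccn3n2)cnc1Cl)c1ccc(F)cc1` differs from compound 1 by a group of 9 heavy atoms (6 carbon, 3 nitrogen; one five-membered aromatic ring with 2 hetero atoms, one six-membered aromatic ring with 2 hetero atoms) in place of a group of 9 heavy atoms (7 carbon, 2 nitrogen; one five-membered aromatic ring with 2 hetero atoms, one six-membered aromatic ring of carbon only), on an aromatic carbon. No measured step speaks to this exchange, so nothing on the numbers shown suggests the change would move the value out of the region where the three measured compounds sit. The step from compound 1 to compound 4 is therefore expected to be a step that the limit leaves unreadable from compound 1 to compound 4, most likely ending again at a limit. Compound 4 is estimated at 15000 nM, within 4000 nM to 60000 nM.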

Compound 4, half-maximal inhibitory concentration: 50 nM
Beside the measured number, compound 4's estimate is 300-fold (2.48 log units) above it; the measured number lies below the stated range.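

In this assay, this position on the aromatic ring with one nitrogen proves decisive: replacing the 1H-benzimidazol-6-yl group gives an at least 240-fold lower number from compound 1 to compound 4 (2.38 log units; beyond the scatter). The three earlier compounds could not show this, since none gave a readable number. Compound 4 is the only one that moves off the limit: the limit of > 12000 nM in this assay, at which 3 of the 4 values shown sit.

A single exchange cannot separate the effect of the extra ring nitrogen from that of losing the hydrogen-bond donor. Going by these compounds, how a methyl or an amine on the entering group of compound 4 would affect the value remains open.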